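The compounds below may be only part of what the source reports. "The series", "measured", "known", "first", "only" and "open" are said of these compounds alone.

Measured so far in a physicochemical assay for solubility, at pH 7.4; on this read-out higher numbers stand for higher solubility and lower numbers for lower solubility:
- compound 1 `CN(C)C1(C)CN(c2c(F)cc3c(=O)c(C(=O)O)cn(C4CC4)c3c2F)C1` at 23.6 ug/mL
- compound 2 `C[C@H]1[C@H](N)CN1c1c(F)c(N)c2c(=O)c(C(=O)O)cn(C3CC3)c2c1F` at 37.7 ug/mL

Compound 2 lies within the scatter of compound 1, so on these two numbers neither stands apart in this assay as yet. Compound 3 `C[C@H]1[C@H](N)CN1c1c(F)cc2c(=O)c(C(=O)O)cn(C3CC3)c2c1F` has hydrogen in place of amino on an aromatic carbon of compound 2 (hydrogen in place of amino on an aromatic carbon). Within the data shown here, no measured pair shows this change, so only a weak expectation is available. The expected step is a 1.3-fold higher number from compound 2 to compound 3 (0.12 log units; within the scatter) in this assay, a small rise that stays within the scatter. The estimated value for compound 3 is 50 ug/mL (18 ug/mL to 140 ug/mL) as the expected range.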

Compound 3, solubility: 23.2 ug/mL
Beside the measured number, compound 3's estimate is 2.2-fold (0.33 log units) above it; the measured number falls inside the stated range.
By their numbers in this assay, from the lowest: compounds 3, 1 and 2 (each within the scatter of the next).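

In this assay, hydrogen in place of amino on the aromatic carbon gives a 1.6-fold lower number from compound 2 to compound 3 (0.21 log units; within the scatter) and so does not separate the two groups at this position. At the other changed site, the group of 6 heavy atoms in place of the group of 8 heavy atoms gives a 1.0-fold lower number from compound 1 to compound 3 (0.01 log units; within the scatter) and likewise separates nothing. No supporting measurement bears on either step.

Open, from the compounds shown here alone, is whether methoxy or a longer chain on the same aromatic carbon would give a step beyond the scatter. Also open, going by these compounds, is whether a carboxamide in place of the carboxylic acid would do so.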